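The source may report more compounds than this note shows. Statements on the series, on what has been measured and on what is new or still open speak of the compounds shown alone.

Compound 2 `CC(C)C[C@H](NC(=O)OCc1ccccc1)C(=O)NCCNc1ccc(OC2CCCCC2)cc1` sits second highest of three numbers in an assay on isolated protein for inhibition of cathepsin S (Homo sapiens) (on this read-out higher numbers stand for weaker inhibition and lower numbers for stronger inhibition), where compound 2 gives 1200 nM. Compound 1 `COc1ccc(C(=O)N[C@@H](CC(C)C)C(=O)NCCNc2ccc(OCC3CCCC3)cc2)cc1` gives 480 nM in this assay, a lower number that lies beyond the scatter, and compound 3 `CCc1ccc(C(=O)N[C@@H](CC(C)C)C(=O)NCCNc2ccc(OCc3ccccc3)cc2)cc1` gives 4900 nM, a higher number that also lies beyond the scatter; neither pair differs from compound 2 in only one place, so their numbers stand on their own. Compound 4 `CC(C)C[C@H](NC(=O)OCc1ccccc1)C(=O)NCCNc1ccc(OC2CCCC2)cc1` differs from compound 2 by cyclopentyl in place of cyclohexyl on an oxygen on an aromatic ring. Among the compounds with values here, no single-change step among the measured compounds speaks to this change, so the step from compound 2 to compound 4 in this assay is expected to stay within the scatter, as no change at the digits printed from compound 2 to compound 4 (within the scatter). For compound 4 the estimate in this assay is 1200 nM, with a range from 500 nM to 3000 nM.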

Compound 4, half-maximal inhibitory concentration: 4400 nM
Estimate against measurement, compound 4: 3.7-fold (0.56 log units) below; measured number above the stated range.
By their numbers in this assay, from the lowest: compound 1; then compound 2; then compounds 4 and 3 (each within the scatter of the next).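

In this assay, within the data shown here, the swap of cyclohexyl for cyclopentyl on an oxygen on an aromatic ring gives a 3.7-fold higher number from compound 2 to compound 4 (0.56 log units; beyond the scatter) and so provides the first single-change reading at this position. Removing one ring carbon, with no change in hydrogen-bond donors, acceptors or charge, is enough to weaken inhibition beyond the scatter. Nothing available explains this step.

From the compounds shown here alone, whether cyclobutyl, cycloheptyl or an open isopropyl chain on this oxygen would continue the trend remains open. This single step also cannot show whether the same swap would have a similar effect on a different core.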